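The source may report more compounds than this note shows. Statements on the series, on what has been measured and on what is new or still open speak of the compounds shown alone.

Three chalcones sharing the same prenylated core have been measured in an ADME assay on MCF7-DOX cells (Homo sapiens) for cytotoxicity, read by MTT assay, with a stated time of 48 h; a higher number here means a weaker inhibitor, a lower number a stronger inhibitor. Compound 1 `COc1cc(OC)c(C(=O)/C=C/c2ccc(Cl)cc2)c(O)c1CC=C(C)C` carries a 4-chlorophenyl group and gives 43400 nM. Compound 2 `COc1cc(OC)c(C(=O)/C=C/c2cccc([N+](=O)[O-])c2)c(O)c1CC=C(C)C` carries a 3-nitrophenyl group instead, and in this assay compound 2 gives 57000 nM. The step of a 1.3-fold higher number from compound 1 to compound 2 (0.12 log units; within the scatter) keeps the two values within the scatter of each other, so compound 2 stands alongside compound 1 rather than apart from it. Compound 3 `CCCCc1c(OC)cc(OC)c(C(=O)/C=C/c2cccc(N3CCNCC3)c2)c1O`, with a butyl chain on the core and a piperazinyl group on the aryl ring, reaches only a limit in this assay, reported as > 100000 nM. That entry is the limit of > 100000 nM in this assay, at which 1 of the 3 values shown sits, and so offers no number to set against the others.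

Compound 4 `COc1cc(OC)c(C(=O)/C=C/c2cccc(F)c2)c(O)c1CC=C(C)C` has not yet been measured. It differs from compound 2 by fluoro in place of nitro on an aromatic carbon. Going by the values given here, the only measured step that bears on a change at the aryl ring is a 1.3-fold higher number from compound 1 to compound 2 (0.12 log units; within the scatter), and that exchange of one substituent for another stayed within the scatter. On that basis no step beyond the scatter is expected in this assay. Compound 4 is therefore estimated to give 50000 nM, with a range from 20000 nM to 130000 nM. This estimate corresponds to an expected step of a 1.1-fold lower number from compound 2 to compound 4 (0.06 log units; within the scatter).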

Compound 4, half-maximal inhibitory concentration: 45400 nM
Compound 4: middle estimate off by 1.1-fold (0.04 log units), on the high side; the measured number falls inside the stated range.
By their numbers in this assay, from the lowest: compounds 1, 4 and 2 (each within the scatter of the next). At a limit, above all of these: compound 3.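

In this assay, the exchange of nitro for fluoro on this aromatic carbon gives a 1.3-fold lower number from compound 2 to compound 4 (0.10 log units; within the scatter), so at this place a group with hydrogen-bond acceptors gives way to one without any while the numbers stay within the scatter of each other. Going by these compounds alone, the exchange of the 4-chlorophenyl group for the 3-fluorophenyl group gives a 1.0-fold higher number from compound 1 to compound 4 (0.02 log units; within the scatter), so compound 1, compound 2 and compound 4 now form a set of three on the shared core with no step among them beyond the scatter, although both the substituent and its place on the ring differ between the first and last of these. Nothing in the data gives a measured property that bears on these exchanges.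

Only chloro, nitro and fluoro are shown on this ring with the shared core, so what an amine, a carboxylic acid or a longer chain would do there remains open. Compound 3 gives > 100000 nM, which is a limit and not a number, and its steps cannot be read, so the separate parts played by its butyl chain and its piperazinyl group stay unresolved.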